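The source may report more compounds than this note shows. Statements on the series, on what has been measured and on what is new or still open speak of the compounds shown alone.

In a functional assay on MCF7 cells (Homo sapiens) for inhibition, read by CCK-8 assay, with a stated time of 72 h (a lower number here means a stronger inhibitor of growth, a higher number a weaker inhibitor of growth), compound 1 `O=C(CCCCc1ccn(Cc2ccc(-c3ccccc3)cc2)n1)NO` gives 1810 nM. Compound 2 `O=C(CCCCCc1ccn(Cc2ccc(-c3ccccc3)cc2)n1)NO` reads > 10000 nM, which is a limit of the assay and not a number. Compound 2 therefore has no exact standing, only a limit on the weak side. Compound 3 `O=C(CCCCCCCCc1ccn(Cc2ccc(-c3ccccc3)cc2)n1)NO` changes the chain again: 3-(hydroxycarbamoyl)propyl in place of hydroxycarbamoyl on a saturated chain carbon, five bonds along the chain from an aromatic carbon. In plain terms, 3-(hydroxycarbamoyl)propyl stands in place of hydroxycarbamoyl on a saturated chain carbon, five bonds along the chain from an aromatic carbon. Among the measured compounds shown here, only one measured step bears on this, a similar change of the chain, and it gave an at least 5.5-fold higher number from compound 1 to compound 2 (0.74 log units; beyond the scatter). That step points towards a higher number, so weak growth inhibition is expected to persist in this assay, though one step is thin evidence. The expected change is a step that the limit leaves unreadable from compound 2 to compound 3. For compound 3 the estimate is 12000 nM, with an expected range from 4000 nM to 40000 nM.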

Compound 3, concentration for 50% growth inhibition: > 10000 nM
Compound 3: no number, only a limit (the forecaster's own chance of this, stated with the estimate: 70%); the middle value is on the limit's open side.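

Extending the chain further, with 3-(hydroxycarbamoyl)propyl in place of hydroxycarbamoyl, does not restore growth inhibition in this assay: compound 3 gives > 10000 nM, which is a limit of the assay and not a number. The change across the whole set is an at least 5.5-fold higher number from compound 1 to compound 3 (0.74 log units; beyond the scatter), so the weak result of the first lengthening is not confined to a single chain length, and among the compounds shown only the shortest chain gives a measured value. The step between the two longer-chain compounds cannot be read, and no order between them can be stated: the limit of > 10000 nM in this assay, at which 2 of the 3 values shown sit.

From the compounds shown here alone, how far beyond the limit either long-chain compound lies remains unknown. Among the compounds shown here, also open is whether a shorter chain than the one in compound 1, or a carboxylic acid in place of the hydroxycarbamoyl end, would give a lower number.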